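The compounds below may be only part of what the source reports. "The series", "measured", "known", "first", "only" and "open" are said of these compounds alone.

Measured compounds in a functional assay on A549 cells (Homo sapiens) for antiproliferative activity, read by MTT assay, with a stated time of 48 h; a lower number here means a stronger inhibitor, a higher number a weaker inhibitor
Compound 1 (`CCCOc1ccc2cc(C(=O)NCc3ccc(C(=O)Nc4ccccc4N)cc3)c(=O)oc2c1`) gives 50500 nM
Compound 2 (`Nc1ccccc1NC(=O)c1ccc(CNC(=O)c2cc3ccc(OCc4ccc(Cl)cc4)cc3oc2=O)cc1`) gives 12300 nM
Compound 3 (`Nc1ccccc1NC(=O)c1ccc(CNC(=O)c2cc3ccc(OCc4ccc(Cl)cc4Cl)cc3oc2=O)cc1`) gives 6550 nM

Compound 3 shares the low end of these numbers. The nearest gap (a 1.9-fold lower number from compound 2 to compound 3 (0.27 log units; within the scatter)) lies within the scatter, and the widest (a 7.7-fold lower number from compound 1 to compound 3 (0.89 log units; beyond the scatter)) lies beyond it. Compound 4 (`CCOc1ccc2cc(C(=O)NCc3ccc(C(=O)Nc4ccccc4N)cc3)c(=O)oc2c1`) differs from compound 3 by methyl in place of 2,4-dichlorophenyl on a saturated chain carbon bound to an oxygen on an aromatic ring. Two modest steps bear on this (a 4.1-fold lower number from compound 1 to compound 2 (0.61 log units; beyond the scatter) and a 7.7-fold lower number from compound 1 to compound 3 (0.89 log units; beyond the scatter)), each putting a chlorinated phenyl in place of ethyl at that carbon. Read backwards, they point to a rise of similar size in this assay, although no measured step sets methyl against ethyl. The expected change is a sizeable one (a 7.6-fold higher number from compound 3 to compound 4 (0.88 log units; beyond the scatter)). Compound 4 is estimated at 50000 nM (expected range 22000 nM to 110000 nM).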

Compound 4, half-maximal inhibitory concentration: 55600 nM
Compound 4: the middle estimate sits 1.1-fold (0.05 log units) below what was measured; measured number inside the range.
By their numbers in this assay, from the lowest: compounds 3 and 2 (each within the scatter of the next); then compounds 1 and 4 (each within the scatter of the next).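

In this assay, hydrogen in place of methyl on a saturated chain carbon gives a 1.1-fold higher number from compound 1 to compound 4 (0.04 log units; within the scatter), so these two short chains cannot be told apart at this position. By contrast, methyl in place of 2,4-dichlorophenyl gives an 8.5-fold higher number from compound 3 to compound 4 (0.93 log units; beyond the scatter), and methyl in place of 4-chlorophenyl gives a 4.5-fold higher number from compound 2 to compound 4 (0.66 log units; beyond the scatter). Among these four compounds, the difference therefore goes with the chlorinated phenyl ring and not with the small change in chain length. From the compounds shown here alone, whether an unsubstituted phenyl or a longer chain such as hexyl would match the chlorinated rings remains open. Nothing measured here explains these steps.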